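The compounds below may be only part of what the source reports. "The series", "measured", "known", "first", "only" and "open" are said of these compounds alone.

Measured so far in a functional assay on HepG2 cells (Homo sapiens) for cytotoxicity, read by MTT assay; on this read-out lower numbers stand for stronger inhibition and higher numbers for weaker inhibition:
Compound 1 `COc1ccc(/C=C/C(=O)c2ccc(OC)c3c2OC(C)(C)C=C3)cc1OCC=C(C)C`: > 10000 nM
Compound 2 `COc1ccc(/C=C/C(=O)c2ccc(OC)c3c2OC(C)(C)C=C3)cc1OC(=O)c1ccc(Br)cc1`: 680 nM

Compound 1 reads > 10000 nM, which is a limit of the assay and not a number. Among the measured compounds shown here, compound 2 gives 680 nM, the only true number so far, so it has no second number to be ranked against.

The next structure is compound 3 `COc1ccc(/C=C/C(=O)c2ccc(OC)c3c2OC(C)(C)C=C3)cc1CS(C)(=O)=O`, and the change is (methylsulfonyl)methyl in place of ((4-bromophenyl)carbonyl)oxy on an aromatic carbon. Put simply, (methylsulfonyl)methyl stands in place of ((4-bromophenyl)carbonyl)oxy on an aromatic carbon, ortho to a methoxy group. For the measured compounds named here, compound 3 thus loses the (4-bromophenyl)carbonyl whose arrival came with the large step of an at least 14-fold lower number from compound 1 to compound 2 (1.16 log units; beyond the scatter), the one measured step bearing on this change. A sizeable move to a higher number is therefore expected in this assay, although the incoming group has not been measured on this core, which keeps the forecast uncertain. The expected size of the change is a 6.6-fold higher number from compound 2 to compound 3 (0.82 log units; beyond the scatter). For compound 3 the estimate is 4500 nM, with an expected range of 1200 nM to 17000 nM.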

Compound 3, half-maximal inhibitory concentration: 9180 nM
Compound 3: the middle estimate sits 2.0-fold (0.31 log units) below what was measured; measured number inside the range.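

Replacing ((4-bromophenyl)carbonyl)oxy with (methylsulfonyl)methyl in this assay gives a 14-fold higher number from compound 2 to compound 3 (1.13 log units; beyond the scatter) and the stronger inhibition seen with compound 2 is lost when this group leaves a position ortho to a methoxy group. The two groups have the same number of hydrogen-bond acceptors and no hydrogen-bond donors, so that count does not account for the gap; the change that stands out in the counts is the loss of the six-membered aromatic ring and the smaller number of heavy atoms. The remaining step, an at least 1.0-fold lower number from compound 1 to compound 3 (0.03 log units; that floor lies within the scatter) gives only a floor and cannot be read as a real size. The value of compound 1 is a limit and not a number: the limit of > 10000 nM in this assay, at which 1 of the 3 values shown sits.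

The compounds shown leave open which part of the ((4-bromophenyl)carbonyl)oxy group goes with the stronger inhibition: the bromine, the aromatic ring or the carbonyl. A phenylcarbonyl group without the bromine, or a 4-bromobenzyl group on the same oxygen, would help to separate these parts.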